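From (2-fluorophenyl)amino to pyrrolidin-1-yl on a shared core

The source may report more compounds than this note shows. Statements on the series, on what has been measured and on what is new or still open speak of the compounds shown alone.

Going by the values given here, in a functional assay on ECa-109 cells for inhibition, with ECa-109 cell line (Homo sapiens) as the target, read by sulforhodamine B assay (on this read-out higher numbers stand for weaker inhibition and lower numbers for stronger inhibition), compound 1 `O=C1C(Nc2ccccc2F)=CC(=O)c2c1nc1n2[C@H]2OC[C@@H](O)[C@H]2OC1` gives 2660 nM, the only true number among the values shown. The question is what happens in compound 4 `O=C1C(N2CCCC2)=CC(=O)c2c1nc1n2[C@H]2OC[C@@H](O)[C@H]2OC1`, where pyrrolidin-1-yl stands in place of (2-fluorophenyl)amino on a double-bonded ring carbon: pyrrolidin-1-yl in place of (2-fluorophenyl)amino on a double-bonded ring carbon.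

Two further compounds offer indirect guidance. Compound 2 `O=C1C=C(N2CCC2)C(=O)c2c1nc1n2[C@H]2OC[C@@H](O)[C@H]2OC1` gives > 16000 nM, which is a limit of the assay and not a number. Compound 3 `O=C1C=C(NC2CCCCC2)C(=O)c2c1nc1n2[C@H]2OC[C@@H](O)[C@H]2OC1` gives > 16000 nM, which is also a limit. Between these two lies a step that the two limits leave unreadable from compound 2 to compound 3, so no size can be taken from that step. Among the compounds with values here, neither compound differs from compound 1 or compound 4 in one place only, and no measured step leads directly to compound 4.

What remains is the limit of > 16000 nM in this assay, at which 2 of the 3 values shown sit, which leans toward weaker inhibition in this assay for compound 4 without fixing a size. The expected change is a 2.6-fold higher number from compound 1 to compound 4 (0.42 log units; beyond the scatter), toward weaker inhibition and probably beyond the usual scatter, though this estimate is uncertain. A limit rather than a number is also possible. For compound 4 the estimated value is 7000 nM, with an expected range from 2000 nM to 20000 nM.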

Compound 4, half-maximal inhibitory concentration: > 16000 nM
Compound 4: only a limit was reported; the forecaster's own chance of this, stated with the estimate: 35%; middle value at least 2.2-fold (0.35 log units) away from the limit.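

In this assay, going by these compounds alone, replacing (2-fluorophenyl)amino with pyrrolidin-1-yl on a double-bonded ring carbon gives an at least 6.0-fold higher number from compound 1 to compound 4 (0.77 log units; beyond the scatter), the first step with a readable lower bound and the first measured at this place. The value of compound 4, > 16000 nM, is a limit of the assay and not a number. Compound 1 therefore remains the only compound shown with a true number, while compound 4 joins the other two compounds at the limit: the limit of > 16000 nM in this assay, at which 3 of the 4 values shown sit.

The change removes the aromatic ring, the fluorine and the hydrogen-bond donor together, so the compounds shown cannot tell which of these departures accounts for the step, and the limit leaves its full size unknown. Plain phenylamino would address the fluorine, N-methyl-(2-fluorophenyl)amino the amine hydrogen, and cyclopentylamino the aromatic ring, each on the same double-bonded ring carbon, but none of these groups is among the compounds shown.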